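The source may report more compounds than this note shows. Statements on the series, on what has been measured and on what is new or still open speak of the compounds shown alone.

Compound 1 `O[C@@H](c1ccccc1)[C@H]1CO[C@H](c2ccccc2)[C@@H](C/C=C/c2ccncc2)C1` is tested in a functional assay on HeLa cells (Homo sapiens) for cytotoxicity, read by WST assay, with a stated time of 48 h (on this read-out higher numbers stand for weaker inhibition and lower numbers for stronger inhibition), and gives only a limit there, > 100000 nM, so its true value is not known and it stands at the limit of > 100000 nM in this assay, at which 1 of the 3 values shown sits. Two related compounds carry methoxy groups: compound 2 `COc1cccc([C@H]2OC[C@H]([C@@H](O)c3ccc(OC)c(OC)c3)C[C@@H]2C/C=C/c2ccc(OC)c(OC)c2)c1` gives 21800 nM, and compound 3 `COc1ccc(/C=C/C[C@@H]2C[C@H]([C@H](O)c3ccc(OC)c(OC)c3)CO[C@H]2c2ccc(OC)c(OC)c2)cc1OC` gives 28700 nM, the two within the scatter of each other. No step between measured compounds is shown. Compound 4 `CCCCCC/C=C/C[C@H]1C[C@@H]([C@@H](O)c2ccccc2)CO[C@@H]1c1ccccc1` differs from compound 1 by hexyl in place of pyridin-4-yl on a double-bonded chain carbon bound to a double-bonded chain carbon. Without a measured step to rest on, he expects the change from compound 1 to compound 4 to bring modestly stronger inhibition, possibly no more than the scatter, an at least 1.6-fold lower number from compound 1 to compound 4 (0.22 log units; that floor lies within the scatter). For compound 4 he estimates 60000 nM, between 15000 nM and 200000 nM.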

Compound 4, half-maximal inhibitory concentration: 7400 nM
Compound 4: the middle estimate sits 8.1-fold (0.91 log units) above what was measured; the measured number lies below the stated range.
By their numbers in this assay, from the lowest: compound 4; then compounds 2 and 3 (each within the scatter of the next). At a limit, above all of these: compound 1.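

In this assay, hexyl in place of pyridin-4-yl gives an at least 13-fold lower number from compound 1 to compound 4 (1.13 log units; beyond the scatter), so this position, on a double-bonded chain carbon bound to a double-bonded chain carbon, does affect the read-out. The true size of the step remains unknown, as compound 1 gives only a limit of the assay: the limit of > 100000 nM in this assay, at which 1 of the 4 values shown sits.

The compounds shown leave open whether the difference follows from losing the aromatic ring and its nitrogen or from the hexyl chain itself. A piperidin-4-yl group or a longer chain at this position would help separate these.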